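The source may report more compounds than this note shows. Statements on the series, on what has been measured and on what is new or still open speak of the compounds shown alone.

Of the compounds shown here, three with the same core have been measured so far, and they differ in the groups carried on the double-bonded chain that hangs from that core. Compound 1 `CCOC(=O)C(=Cc1c(-c2ccccc2)[nH]c2ccccc12)C(=O)OCC` gives 3800 nM in a functional assay on NCI-H460 cells (Homo sapiens) for inhibition, read by sulforhodamine B assay, with a stated time of 48 h; on this read-out higher numbers stand for weaker inhibition of growth and lower numbers for stronger inhibition of growth. Compound 2 `CC(=O)/C(=C\c1c(-c2ccccc2)[nH]c2ccccc12)S(=O)(=O)c1ccccc1` gives 1100 nM in this assay, and compound 3 `COc1ccc(-c2[nH]c3ccc(OC)cc3c2C=C(C#N)C#N)cc1` gives 472 nM in this assay. On these three numbers compound 2 stands second highest: its nearest neighbour is compound 3, whose number is lower, and its furthest is compound 1, whose number is higher, and both of those gaps lie beyond the usual scatter of repeated measurements.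

Compound 4 `N#C/C(=C\c1c(-c2ccccc2)[nH]c2ccccc12)S(=O)(=O)c1ccccc1` has not yet been measured. It differs from compound 2 in a single place: cyano in place of acetyl on a double-bonded chain carbon bound to a double-bonded chain carbon and a sulfonyl sulfur. Within the data shown here, no pair of measured compounds differs in just this way, so there is no directly matching step to lean on, and the expectation must rest on the three numbers in hand. Among the measured compounds shown here, compound 3, the only measured compound carrying cyano on its chain, gives 472 nM in this assay, the lowest of the three. The step from compound 2 to compound 4 is therefore expected to be modest and directed toward a lower number, a 1.6-fold lower number from compound 2 to compound 4 (0.20 log units; within the scatter). Compound 4 is estimated at 700 nM, with a likely range from 250 nM to 2000 nM.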

Compound 4, concentration for 50% growth inhibition: 2700 nM
Compound 4: the middle estimate sits 3.9-fold (0.59 log units) below what was measured; measured number above the stated range.
By their numbers in this assay, from the lowest: compound 3; then compound 2; then compounds 4 and 1 (each within the scatter of the next).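

In this assay, putting cyano in place of acetyl on this chain carbon gives a 2.5-fold higher number from compound 2 to compound 4 (0.39 log units; beyond the scatter), so this single change weakens growth inhibition by more than the usual scatter. Among these compounds, this is the first direct reading of the change, and it shows that the cyano group does not bring the low number of compound 3 (472 nM) to this position: compound 3 differs from compound 4 in more than one place, so its number could not speak for this swap alone. Acetyl and cyano have the same counts of hydrogen-bond donors and acceptors, so those counts do not separate them, and no measurement here accounts for the step.

Still open, as far as these compounds go, is how other groups would fare on this same carbon, such as a carboxylic acid, a primary amide or a longer ketone like propanoyl, and whether the order of acetyl and cyano depends on the size of the group or on something else. From the compounds shown here alone, it is also open whether the same swap would give a step of similar direction and size with a group other than the sulfonyl on this carbon, or with methoxy groups on the shared core.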